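Aryl hydrazone variation on the shared core

This account rests on a few compounds, and the source may have more. Where it says the series, first, only, none or still open, it means among the compounds named here.

Compound 3 `COc1cc2c(Oc3ccc(NC(=O)N/N=C/c4ccc(O)cc4)cc3F)ccnc2cc1OCCCN1CCCCC1` gives 470 nM in a functional assay on HT-29 cells (Homo sapiens) for cytotoxicity, read by MTT assay, with a stated time of 72 h (on this read-out lower numbers stand for stronger inhibition and higher numbers for weaker inhibition), and stands second highest of the three numbers. Compound 2 `COc1cc2c(Oc3ccc(NC(=O)N/N=C/c4ccc(Cl)cc4Cl)cc3F)ccnc2cc1OCCCN1CCCCC1` gives 370 nM and compound 1 `COc1cc2c(Oc3ccc(NC(=O)N/N=C/c4ccc(C(F)(F)F)cc4)cc3F)ccnc2cc1OCCCN1CCCCC1` gives 660 nM; the steps of a 1.3-fold higher number from compound 2 to compound 3 (0.10 log units; within the scatter) and a 1.4-fold lower number from compound 1 to compound 3 (0.15 log units; within the scatter) both lie within the scatter, as does a 1.8-fold lower number from compound 1 to compound 2 (0.25 log units; within the scatter). Compound 4 `COc1cc2c(Oc3ccc(NC(=S)N/N=C/c4ccc(Cl)cc4)cc3F)ccnc2cc1OCCCN1CCCCC1` differs from compound 3 by a group of 12 heavy atoms (8 carbon, 2 nitrogen, 1 sulfur, 1 chlorine; one six-membered aromatic ring of carbon only) in place of a group of 12 heavy atoms (8 carbon, 2 nitrogen, 2 oxygen; one six-membered aromatic ring of carbon only), on a nitrogen on an aromatic ring. Among the compounds with values here, all three measured steps vary only the aromatic ring on the carbon with a double bond to nitrogen and none moves beyond the scatter; no measured pair exchanges the oxygen of the carbonyl for sulfur, so that part of the change has no precedent. The expected step is therefore a 1.0-fold lower number from compound 3 to compound 4 (0.02 log units; within the scatter), nothing beyond the scatter. The estimate for compound 4 is 450 nM, with a range from 150 nM to 1400 nM.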

Compound 4, half-maximal inhibitory concentration: 190 nM
For compound 4 the middle estimate is 2.4-fold (0.37 log units) above the measured one; the measured number falls inside the stated range.
By their numbers in this assay, from the lowest: compounds 4, 2, 3 and 1 (each within the scatter of the next, the first and the last beyond it).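

Within the data shown here, exchanging this group on a nitrogen on an aromatic ring gives, in this assay, a 2.5-fold lower number from compound 3 to compound 4 (0.39 log units; beyond the scatter), the first step to pass beyond the scatter, whereas aromatic ring changes alone stayed within it. Sulfur and chlorine enter together here, so the step belongs to the whole group and cannot be assigned to either atom. Nothing at hand accounts for the step.

The compounds shown include no pair that exchanges the carbonyl oxygen for sulfur alone. On these data alone, how an amine or a carboxylic acid on the aromatic ring would read also stays open.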